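Swapping the Silicon-Bound Aryl Group in Compound 2

The source may report more compounds than this note shows. Statements on the series, on what has been measured and on what is new or still open speak of the compounds shown alone.

Compound 2 `CCN(C/C=C/C#CC(C)(C)C)Cc1cccc(OC[Si](C)(C)c2ccc(C(N)=O)cc2)c1` gives 5000 nM in a functional assay on liver (Sus scrofa) for inhibition of squalene monooxygenase (Homo sapiens), using microsomes (on this read-out lower numbers stand for stronger inhibition and higher numbers for weaker inhibition), the highest of the two numbers measured, and stands alone at that end. Going by the values given here, its neighbour compound 1 `CCN(C/C=C/C#CC(C)(C)C)Cc1cccc(OC[Si](C)(C)c2ccc(C)cc2)c1` gives 120 nM, and the single measured step of a 42-fold higher number from compound 1 to compound 2 (1.62 log units; beyond the scatter) shows how much weaker the carbamoyl variant is. Compound 3 `CCN(C/C=C/C#CC(C)(C)C)Cc1cccc(OC[Si](C)(C)c2ccccc2-c2ccsc2)c1` changes compound 2 by 2-(thiophen-3-yl)phenyl in place of 4-carbamoylphenyl on a silicon. Among the compounds with values here, no measured step covers adding a thiophene, but the change takes away the carbamoyl whose arrival produced the large loss in this assay, so a step back toward compound 1 is expected, estimated as a 17-fold lower number from compound 2 to compound 3 (1.22 log units; beyond the scatter), giving compound 3 an expected 300 nM with a range from 60 nM to 1500 nM.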

Compound 3, half-maximal inhibitory concentration: 10000 nM
Compound 3: the middle estimate sits 33-fold (1.52 log units) below what was measured, and the stated range ends below it.
By their numbers in this assay, from the lowest: compound 1; then compounds 2 and 3 (each within the scatter of the next).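

Taking away the carbamoyl does not by itself bring back inhibition: in this assay there is a 2.0-fold higher number from compound 2 to compound 3 (0.30 log units; within the scatter), so these two groups on the silicon cannot be told apart. Measured against the 4-methylphenyl group, there is an 83-fold higher number from compound 1 to compound 3 (1.92 log units; beyond the scatter), which shows that this position does not accept every aryl group equally. Still open, as far as these compounds go, is how plain phenyl on this silicon would behave, or a phenyl carrying an amine or a carboxylic acid. No available evidence bears on this result.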